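A few compounds are considered here, and "the series" means these few. Any claim that something is new, unique, unknown or untested is made for them only; others in the source may bear on it.

In an assay on cells for inhibition of Pendrin (Mus musculus), read by fluorescence, with a stated time of 10 min (a higher number here means a weaker inhibitor, a lower number a stronger inhibitor), compound 3 `Cn1nc(COc2cc(F)cc(F)c2)c2c1CCN(C(=O)Nc1ccc(Br)cc1)C2` gives 3300 nM. Compound 1 `Cn1nc(COc2cccc(F)c2)c2c1CCN(C(=O)Nc1ccc(Cl)cc1)C2` gives 6600 nM, and compound 2 `Cn1nc(COc2ccc(F)c(F)c2)c2c1CCN(C(=O)Nc1ccc(Cl)cc1)C2` gives 4600 nM, so compound 3 stands at the low end of the three numbers shown, yet its gaps to both other compounds lie within the scatter, and nothing separates them with confidence. Among the compounds with values here, the one measured step, a 1.4-fold lower number from compound 1 to compound 2 (0.16 log units; within the scatter), concerns a fluoro added to the aromatic ring of the ether and leaves the urea part untouched. Compound 4 `Cn1nc(COc2cc(F)cc(F)c2)c2c1CCN(C(=S)NC1CCCCC1)C2` differs from compound 3 in that (a group of 9 heavy atoms (7 carbon, 1 nitrogen, 1 sulfur; one six-membered non-aromatic ring of carbon only) in place of a group of 10 heavy atoms (7 carbon, 1 nitrogen, 1 oxygen, 1 bromine; one six-membered aromatic ring of carbon only), on an amine nitrogen in a ring). Within the data shown here, no measured step covers this exchange, so the expectation rests only on the narrow spread of the three numbers and carries a wide range. Compound 4 is expected to give 5000 nM, between 1500 nM and 20000 nM. The step expected from compound 3 to compound 4 is a 1.5-fold higher number from compound 3 to compound 4 (0.18 log units; within the scatter).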

Compound 4, half-maximal inhibitory concentration: > 10000 nM
Compound 4 was reported as a limit (the forecaster's own chance of this, stated with the estimate: 10%); middle value at least 2.0-fold (0.30 log units) from the limit.
By their numbers in this assay, from the lowest: compounds 3, 2 and 1 (each within the scatter of the next). At a limit, above all of these: compound 4.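

Within the data shown here, the exchange on the amine nitrogen in a ring gives the first step here beyond the scatter in this assay: an at least 3.0-fold higher number from compound 3 to compound 4 (0.48 log units; beyond the scatter). This position therefore responds to change, whereas the fluoro exchange on the ether's aromatic ring did not, with a 1.4-fold lower number from compound 1 to compound 2 (0.16 log units; within the scatter). Compound 4 stands as a limit, not a number: the limit of > 10000 nM in this assay, at which 1 of the 4 values shown sits.

The exchange replaces the aromatic ring with a non-aromatic one and oxygen with sulfur together, so the compounds shown cannot separate the two changes. As far as these compounds go, how a pyridine ring or an acetyl group on this nitrogen would read remains open.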